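The source may report more compounds than this note shows. Statements on the series, on what has been measured and on what is new or still open speak of the compounds shown alone.

Of the compounds shown here, two sharing one core have so far been measured in an in vitro ADME assay on microsomes from liver (Homo sapiens) for metabolic stability; a higher number here means faster removal of the compound, a lower number slower removal. For the measured compounds named here, in it, compound 1 `N#Cc1cc(Cl)c(NC(=O)N2CCN3C(=O)N([C@H]4C[C@@H]4c4ccccc4)C(=O)[C@@H]3C2)c(Cl)c1` gives 66000 mL.min-1.g-1 and compound 2 `O=C(Nc1cccc(Cl)c1Cl)N1CCN2C(=O)N([C@H]3C[C@@H]3c3ccccc3)C(=O)[C@@H]2C1` gives 73000 mL.min-1.g-1, so compound 2 stands within the scatter of the only other number available. The next compound, compound 3 `O=C(Nc1c(Cl)cc(F)cc1Cl)N1CCN2C(=O)N([C@H]3C[C@@H]3c3ccccc3)C(=O)[C@@H]2C1`, keeps the shared core and alters one group: 2,6-dichloro-4-fluorophenyl in place of 2,3-dichlorophenyl on an amide-type nitrogen. In words, 2,6-dichloro-4-fluorophenyl stands in place of 2,3-dichlorophenyl on an amide-type nitrogen.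

Going by the values given here, only one measured step bears on this change. It is a 1.1-fold higher number from compound 1 to compound 2 (0.04 log units; within the scatter), and it exchanges groups at the same place. Compound 1 carries 2,6-dichloro-4-cyanophenyl there, the name closest to the group entering compound 3, yet that single step shows no change beyond the scatter. Among the compounds with values here, no measured compound carries 2,6-dichloro-4-fluorophenyl itself, so this expectation rests on one step alone. The expected change is a 1.1-fold lower number from compound 2 to compound 3 (0.05 log units; within the scatter), which means none beyond the scatter. In this assay, the estimate for compound 3 is 65000 mL.min-1.g-1, with an expected range from 35000 mL.min-1.g-1 to 120000 mL.min-1.g-1.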

Compound 3, intrinsic clearance in microsomes: 64000 mL.min-1.g-1
The estimate for compound 3 lay 1.0-fold (0.01 log units) above the measured number, within the range that was stated.
By their numbers in this assay, from the lowest: compounds 3, 1 and 2 (each within the scatter of the next).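

The change to 2,6-dichloro-4-fluorophenyl on the amide-type nitrogen gives a 1.1-fold lower number from compound 2 to compound 3 (0.06 log units; within the scatter) in this assay and so adds a third aryl group at this place, again with no change beyond the scatter. The direct exchange of fluoro in place of cyano on an aromatic carbon gives a 1.0-fold lower number from compound 1 to compound 3 (0.01 log units; within the scatter) and is new in kind, since it alters one substituent while the two chlorines named in both groups stay, whereas the earlier step between compound 1 and compound 2 altered the whole substitution of the ring at once. Across compound 1, compound 2 and compound 3, then, neither the cyano-to-fluoro exchange nor the different chlorine arrangements of these groups separates the numbers, and no measurement here offers any explanation for that.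

Going by these compounds, all three groups are chlorinated phenyl rings, so it remains open whether an amine, a carboxylic acid or a methoxy group on that ring, or a saturated group such as cyclohexyl in its place, would move the number beyond the scatter. On these data alone, it also remains open whether a change elsewhere on the shared core would do so.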